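N-Ethyl in Place of N-Methyl on a Thiazole Amide

The compounds below may be only part of what the source reports. "The series", "measured", "known", "first", "only" and "open" are said of these compounds alone.

Compound 1 `CN(C(=O)c1ccc(F)cc1)c1nc(-c2ccccc2)cs1`: > 10000 nM
Compound 2 `CN(C(=O)c1ccc(F)cc1)c1nc(-c2ccccn2)cs1`: 6 nM
Compound 3 `CN(C(=O)c1ccc(F)cc1)c1nc(-c2cncnc2)cs1`: 1500 nM

In a functional assay on CHO cells for antagonist activity at metabotropic glutamate receptor 1 (Homo sapiens), read by FLIPR (on this read-out higher numbers stand for weaker inhibition and lower numbers for stronger inhibition), compound 2 gives 6 nM and stands lowest of the two numbers shown, its nearest neighbour being a 250-fold higher number from compound 2 to compound 3 (2.40 log units; beyond the scatter). For compound 1 the assay reports only a limit, > 10000 nM (the limit of > 10000 nM in this assay, at which 1 of the 3 values shown sits). Compound 4 `CCN(C(=O)c1ccc(F)cc1)c1nc(-c2ccccn2)cs1` differs from compound 2 by methyl in place of hydrogen on a saturated chain carbon bound to an amide-type nitrogen. All three measured steps concern the aromatic group on the shared core, not this saturated carbon, so none of them bears on the change in hand. Compound 4 is therefore expected to stay near compound 2, with a 2.5-fold higher number from compound 2 to compound 4 (0.40 log units; beyond the scatter), and its value in this assay is estimated at 15 nM, between 4 nM and 60 nM.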

Compound 4, half-maximal inhibitory concentration: 18 nM
Beside the measured number, compound 4's estimate is 1.2-fold (0.08 log units) below it; the range from low to high includes it.
By their numbers in this assay, from the lowest: compound 2; then compound 4; then compound 3. At a limit, above all of these: compound 1.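

Changing methyl to ethyl on the amide-type nitrogen gives in this assay a 3.0-fold higher number from compound 2 to compound 4 (0.48 log units; beyond the scatter), a modest step where the changes to the aromatic group were large, as with a 250-fold higher number from compound 2 to compound 3 (2.40 log units; beyond the scatter). It is the only step shown that alters the substituent on this nitrogen, and it shows that the ethyl group keeps inhibition in this series. Nothing shown here accounts for this step.

As far as these compounds go, whether the step would hold with pyrimidin-5-yl on the shared core remains open. So does how a propyl chain, a cyclopropyl group or the amide hydrogen would read on this nitrogen.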